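This account rests on a few compounds, and the source may have more. Where it says the series, first, only, none or still open, it means among the compounds named here.

Compound 1 `O=C(O)CCC/C=C\C[C@H]1[C@@H]2CCC(C2)[C@@H]1NS(=O)(=O)c1ccc([N+](=O)[O-])cc1` gives the lowest of the two numbers measured in a functional assay (plasma) for inhibition, with Oryctolagus cuniculus as the target (on this read-out higher numbers stand for weaker inhibition and lower numbers for stronger inhibition), at 1400 nM; compound 2 `CCCCCCS(=O)(=O)N[C@H]1C2CC[C@H](C2)[C@@H]1C/C=C\CCCC(=O)O` gives 13300 nM, which is a 9.5-fold higher number from compound 1 to compound 2 (0.98 log units; beyond the scatter). Compound 3 `CN(C)c1ccc(S(=O)(=O)N[C@H]2C3CC[C@H](C3)[C@@H]2C/C=C\CCCC(=O)O)cc1` differs from compound 1 in one place: dimethylamino in place of nitro on an aromatic carbon, so that 4-nitrophenyl becomes 4-(dimethylamino)phenyl on the sulfonyl sulfur. Among the measured compounds shown here, no measured step swaps one group for another on that ring; the step from compound 1 to compound 2 exchanges the whole ring for hexyl and is modest. With the ring kept, only a small change in this assay is expected, a 2.1-fold higher number from compound 1 to compound 3 (0.33 log units; beyond the scatter). Compound 3 is therefore estimated at 3000 nM, within 800 nM to 12000 nM.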

Compound 3, half-maximal inhibitory concentration: 7100 nM
Compound 3: the middle estimate sits 2.4-fold (0.37 log units) below what was measured; low and high end bracket the measured number.
By their numbers in this assay, from the lowest: compound 1; then compounds 3 and 2 (each within the scatter of the next).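

In this assay, changing only the group on the ring matters: dimethylamino in place of nitro gives (a 5.1-fold higher number from compound 1 to compound 3 (0.71 log units; beyond the scatter)), so the ring alone does not set the number. Compound 3 also stays within the scatter of the hexyl compound (a 1.9-fold lower number from compound 2 to compound 3 (0.27 log units; within the scatter)), so among these compounds only the 4-nitrophenyl group stands apart. Nothing measured here explains this difference. As far as these compounds go, whether a chloro or methoxy group at this place would resemble nitro or dimethylamino remains open, as does the result for a plain phenyl ring.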